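A Furan for a Substituted Phenyl in Paw Edema

The source may hold more compounds than are shown below. What is called first, only, known or untested is meant among the compounds shown, and "the series" means these compounds.

Measured so far:
Compound 1, `COc1ccc(Cl)c(-c2nnc3sc(Cc4c[nH]c5ccc(OC)cc45)nn23)c1`: 6.1%
Compound 2, `COc1ccc2[nH]cc(Cc3nn4c(-c5ccoc5C)nnc4s3)c2c1`: 16%
Compound 3, `COc1ccc(Cl)c(-c2nnc3sc(Cc4c[nH]c5ccccc45)nn23)c1`: 8.8%

All three compounds were tested in a functional assay on the whole organism (strain Wistar Albino) for inhibition, with Rattus norvegicus as the target, read by paw edema, with a stated time of 1 h, at a dose of 20 mg/kg; a higher number here means more inhibition at the dose given (going by the name of the read-out), a lower number less inhibition. Among the three numbers compound 3 stands second highest. The nearest number belongs to compound 1, the gap being a number 2.7 percentage points higher from compound 1 to compound 3 (within the scatter), and the furthest belongs to compound 2; both gaps lie within the scatter, so no order among the three can be claimed.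

The unmeasured compound 4, `Cc1occc1-c1nnc2sc(Cc3c[nH]c4ccccc34)nn12`, differs from compound 3 in one place: 2-methylfuran-3-yl in place of 2-chloro-5-methoxyphenyl on an aromatic carbon. One measured step carries exactly this change, on the otherwise identical core that holds the methoxy group: a number 9.9 percentage points higher from compound 1 to compound 2 (within the scatter). That step stayed within the scatter. The same change applied to compound 3 is therefore expected to shift the number by a similar amount, in the same direction, without moving beyond the scatter. Compound 4 is thus expected to give 18%, with a range from 6% to 30%. This estimate means a step of a number 9.2 percentage points higher from compound 3 to compound 4 (within the scatter), which is expected to remain within the usual scatter of this assay.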

Compound 4, a percentage reported as inhibition, in the whole organism at one dose (the size of the read-out at that dose, not a potency): 16%
Estimate against measurement, compound 4: 2 percentage points above; low and high end bracket the measured number.
By their numbers in this assay, from the lowest: compounds 1, 3, 2 and 4 (each within the scatter of the next).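

In this assay, for the compounds shown here, placing 2-methylfuran-3-yl instead of 2-chloro-5-methoxyphenyl on the aromatic carbon between two ring nitrogen atoms can now be read on a second core, the one lacking the methoxy group, where it gives a number 7.2 percentage points higher from compound 3 to compound 4 (within the scatter). Side by side, the two readings of this change agree, and this is the first sign that the change behaves alike with or without that methoxy group: the same change on two cores in this assay, a number 9.9 percentage points higher (within the scatter) from compound 1 to compound 2 and a number 7.2 percentage points higher (within the scatter) from compound 3 to compound 4, 2.7 percentage points apart, within the scatter of two such steps

Hydrogen in place of methoxy, earlier seen only with the 2-chloro-5-methoxyphenyl group, can now also be read with 2-methylfuran-3-yl, where it gives no change at the digits printed from compound 2 to compound 4 (within the scatter), and these two readings also agree: the same change on two cores in this assay, a number 2.7 percentage points higher (within the scatter) from compound 1 to compound 3 and no change at the digits printed (within the scatter) from compound 2 to compound 4, 2.7 percentage points apart, within the scatter of two such steps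

Going by these compounds alone, all of these steps stay within the scatter, so the four compounds do not establish a real effect of either change, only that the two changes show no sign of depending on each other. Still open, as far as these compounds go, is whether any group on this aromatic carbon, such as an amine like morpholine or a carboxylic acid, would move the number beyond the scatter.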